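Extending the alkenyl chain of compound 3

The source may report more compounds than this note shows. Statements on the series, on what has been measured and on what is new or still open speak of the compounds shown alone.

- compound 1 `CCCCCC/C=C\CCCCCCCCOC[C@H]1NC[C@H](O)[C@@H]1O`: 2000 nM
- compound 2 `C=CCCCCCCOC[C@@H]1C[C@@H](O)CN1C(=O)OC(C)(C)C`: 23000 nM
- compound 3 `C=CCCCCCCCCCOC[C@@H]1C[C@@H](O)CN1C(=O)OC(C)(C)C`: 39000 nM

In a functional assay on HeLa cells (Homo sapiens) for inhibition, with a stated time of 72 h (a lower number here means a stronger inhibitor, a higher number a weaker inhibitor), compound 3 at 39000 nM stands level with compound 2 within the scatter, while compound 1 shows a clearly lower number. Compound 4 `CCCCCCCC/C=C/CCCCCCCCOC[C@@H]1C[C@@H](O)CN1C(=O)OC(C)(C)C` keeps the core of compound 3 and alters only the end of the chain: a group of 10 heavy atoms (10 carbon; no ring) in place of a group of 3 heavy atoms (3 carbon; no ring), on a saturated chain carbon, eight bonds along the chain from an oxygen on a saturated carbon. Compound 1 has a different core and offers no clean comparison. Because of a 1.7-fold higher number from compound 2 to compound 3 (0.23 log units; within the scatter), a step on a similar chain extension, no shift beyond the scatter is expected in this assay, although the new change is larger. The estimate means a 1.3-fold lower number from compound 3 to compound 4 (0.11 log units; within the scatter). Compound 4 is expected at 30000 nM, within a range of 10000 nM to 80000 nM.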

Compound 4, half-maximal inhibitory concentration: 29500 nM
The estimate for compound 4 lay 1.0-fold (0.01 log units) above the measured number; measured number inside the range.
By their numbers in this assay, from the lowest: compound 1; then compounds 2, 4 and 3 (each within the scatter of the next).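

At this position, eight bonds along the chain from an oxygen on a saturated carbon, this assay shows a 1.3-fold lower number from compound 3 to compound 4 (0.12 log units; within the scatter) when a group of 10 carbon atoms replaces allyl. The earlier step covered a smaller extension, whereas this much larger group still produces no shift beyond the scatter. No evidence on the reason for this is at hand. Still open, as far as these compounds go, is whether an amine or a carboxylic acid at the chain end would shift the number. A fully saturated chain of the same length also remains an open case.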